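Removing the benzyl group from a phenolic oxygen

A few compounds are considered here, and "the series" means these few. Any claim that something is new, unique, unknown or untested is made for them only; others in the source may bear on it.

Both measured compounds sit at the same place in an ADME assay on BJ cells (Homo sapiens) for cytotoxicity, read by CellTiter-Glo and resazurin assay, with a stated time of 72 h; a higher number here means that more compound is needed for the effect, a lower number that less compound is needed. Compound 1 (`CC(C)N(Cc1cccc(OCCCCCC(=O)O)c1)C(=O)c1ccc(-c2ccsc2)cc1`) gives > 26000 nM, which is a limit of the assay rather than a number. Compound 2 (`CC(C)N(Cc1cccc(OCCCCCC(=O)O)c1)C(=O)c1ccc(-c2cccc(OCc3ccccc3)c2)cc1`) likewise gives > 26000 nM, again a limit rather than a number. So compound 2 stands at the limit of > 26000 nM in this assay, at which 2 of the 2 values shown sit, and nothing separates it from the other value shown.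

Compound 3 (`CC(C)N(Cc1cccc(OCCCCCC(=O)O)c1)C(=O)c1ccc(-c2cccc(O)c2)cc1`) differs from compound 2 in one place: hydrogen in place of benzyl on an oxygen on an aromatic ring. Within the data shown here, no step between measured compounds exists to guide the size of this change in this assay. Since compound 2 sits at the limit, and since nothing here points in either direction, the expected step from compound 2 to compound 3 is a step that the limit leaves unreadable from compound 2 to compound 3, none beyond the usual scatter. Compound 3 is therefore estimated at 30000 nM in this assay, within a range from 15000 nM to 80000 nM, most likely reported again only as a limit.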

Compound 3, half-maximal effective concentration: > 26000 nM
Compound 3 was reported as a limit; the forecaster's own chance of this, stated with the estimate: 85%; the middle value does not contradict the limit.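

No step can be read from compound 2 to compound 3 or from compound 1 to compound 3, because all three compounds sit at the same place: the limit of > 26000 nM in this assay, at which 3 of the 3 values shown sit.

The compounds shown leave open how much of each would be needed for the effect in this assay, and whether going from benzyloxy to hydroxy alters that amount.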